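Replacing phenylsulfonyl with methylsulfanyl in compound 2

This account rests on a few compounds, and the source may have more. Where it says the series, first, only, none or still open, it means among the compounds named here.

In a functional assay on BXPC-3 cells (Homo sapiens) for antiproliferative activity, read by MTT assay, with a stated time of 24 h (on this read-out higher numbers stand for weaker inhibition and lower numbers for stronger inhibition), compound 1 `CCn1c(C(=O)NCCN)ccc1C(CC)(CC)c1ccc(OCS(=O)(=O)c2ccccc2)c(C)c1` gives 6430 nM, compound 2 `CCN(CC)CCNC(=O)c1ccc(C(CC)(CC)c2ccc(OCS(=O)(=O)c3ccccc3)c(C)c2)n1CC` gives 6270 nM and compound 3 `CCn1c(C(=O)N[C@H](C)CO)ccc1C(CC)(CC)c1ccc(OCS(=O)(=O)c2ccccc2)c(C)c1` gives 10000 nM. Compound 2 stands level with the other two, with both of its gaps lying within the scatter.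

Compound 4 `CCN(CC)CCNC(=O)c1ccc(C(CC)(CC)c2ccc(OCSC)c(C)c2)n1CC` departs from compound 2 in a part of the structure that none of the others varies: methylsulfanyl in place of phenylsulfonyl on a saturated chain carbon bound to an oxygen on an aromatic ring. Put simply, methylsulfanyl sits in place of phenylsulfonyl on a saturated chain carbon bound to an oxygen on an aromatic ring.

The three measured steps, a 1.0-fold lower number from compound 1 to compound 2 (0.01 log units; within the scatter), a 1.6-fold higher number from compound 2 to compound 3 (0.20 log units; within the scatter) and a 1.6-fold higher number from compound 1 to compound 3 (0.19 log units; within the scatter), all alter the chain on the amide-type nitrogen, and each lies within the scatter. None of them touches the phenylsulfonyl group, so the data offer no direct evidence on this change and give it no direction. With nothing pointing either way, the expected outcome in this assay is no shift beyond the scatter, though with wide uncertainty, and the estimated step is a 1.1-fold higher number from compound 2 to compound 4 (0.05 log units; within the scatter). Compound 4 is estimated at 7000 nM, within an expected range of 2500 nM to 20000 nM.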

Compound 4, half-maximal inhibitory concentration: 5130 nM
Compound 4: middle estimate off by 1.4-fold (0.13 log units), on the high side; low and high end bracket the measured number.
By their numbers in this assay, from the lowest: compounds 4, 2, 1 and 3 (each within the scatter of the next).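

In this assay, going by these compounds alone, the step at this position, a 1.2-fold lower number from compound 2 to compound 4 (0.09 log units; within the scatter), gives the first reading on the group carried by the saturated chain carbon bound to an oxygen on an aromatic ring, as the earlier compounds varied only the chain on the amide-type nitrogen. It shows that, in this pair, phenylsulfonyl with 9 heavy atoms and a six-membered aromatic ring can be replaced by methylsulfanyl with 2 heavy atoms and no ring without a shift beyond the scatter. No measurement shown accounts for this result.

The compounds shown leave open whether methylsulfonyl, a longer alkylsulfanyl chain, an amine or a carboxylic acid at this place would move the number beyond the scatter. They also leave open whether methylsulfanyl behaves the same way when the amide-type nitrogen carries 2-aminoethyl or 1-(hydroxymethyl)ethyl.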